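From Methoxy to Chloro on a Shared Core

A few compounds are considered here, and "the series" means these few. Any claim that something is new, unique, unknown or untested is made for them only; others in the source may bear on it.

Compound 1 `CN(C)c1nc(Cl)nc2c1ncn2[C@H]1C[C@H](N=[N+]=[N-])[C@@H](CO)O1`: > 100000 nM (a limit of the assay)
Compound 2 `COc1nc(N)c2ncn([C@H]3C[C@H](N=[N+]=[N-])[C@@H](CO)O3)c2n1`: 35000 nM

Within the data shown here, in an ADME assay on PBMC cells (Homo sapiens) for cytotoxicity, with a stated time of 5 days (on this read-out higher numbers stand for weaker inhibition and lower numbers for stronger inhibition), compound 2 gives 35000 nM, the only actual number so far. The other result is a limit. Compound 3 `[N-]=[N+]=N[C@H]1C[C@H](n2cnc3c(N)nc(Cl)nc32)O[C@@H]1CO` has chloro in place of methoxy on an aromatic carbon. Among the measured compounds shown here, no measured pair of compounds isolates this change, so no direction can be called with confidence. The estimated 1.2-fold lower number from compound 2 to compound 3 (0.07 log units; within the scatter) is expected to stay within the usual scatter. For compound 3 the estimate is 30000 nM, with an expected range from 8000 nM to 100000 nM.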

Compound 3, half-maximal inhibitory concentration: 35800 nM
Compound 3: middle estimate off by 1.2-fold (0.08 log units), on the low side, within the range that was stated.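

In this assay, chloro in place of methoxy on the aromatic carbon between two ring nitrogen atoms leaves the read-out within the scatter: a 1.0-fold higher number from compound 2 to compound 3 (0.01 log units; within the scatter). Amino in place of dimethylamino, at another place on the shared core, gives a step beyond the scatter: an at least 2.7-fold lower number from compound 1 to compound 3 (0.44 log units; beyond the scatter). That step is only a minimum, since compound 1 stands at a limit of the assay: the limit of > 100000 nM in this assay, at which 1 of the 3 values shown sits.

On these data alone, whether a carboxylic acid or a propoxy chain at the chloro position would also stay within the scatter remains open. As far as these compounds go, the true size of the amino step remains open too.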